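Oxolanyl for Oxazolyl on the Amide Carbonyl

This account rests on a few compounds, and the source may have more. Where it says the series, first, only, none or still open, it means among the compounds named here.

Compound 1, `CCn1c(-c2cnc(C)nc2)nc2c(O[C@H]3CCN(C(=O)C4CC4)C3)ncnc21`: 0.6 L/kg
Compound 2, `CCC(=O)N1CC[C@H](Oc2ncnc3c2nc(-c2cnc(C)nc2)n3CC)C1`: 1.9 L/kg
Compound 3, `CCn1c(-c2ccc(C(F)(F)F)nc2)nc2c(O[C@H]3CCN(C(=O)c4cocn4)C3)ncnc21`: 1.2 L/kg

In an ADME assay (Canis lupus familiaris, strain Beagle) for pharmacokinetics (on this read-out lower numbers stand for narrower distribution and higher numbers for wider distribution into tissues), compound 3 holds the second highest of the three numbers; its value lies within the usual scatter of compound 2 and likewise of compound 1, so no order among them can be claimed. Compound 4, `CCn1c(-c2ccc(C(F)(F)F)nc2)nc2c(O[C@H]3CCN(C(=O)C4CCOC4)C3)ncnc21`, differs from compound 3 by oxolan-3-yl in place of 1,3-oxazol-4-yl on a carbonyl carbon. Within the data shown here, no measured step matches this exchange. Among the measured compounds shown here, the one step at the same carbonyl carbon, a 3.2-fold higher number from compound 1 to compound 2 (0.50 log units; beyond the scatter), shows that changes there can move the number, but it concerns different groups and bears only loosely on this one. Compound 4 is therefore expected to show a step of a 1.1-fold higher number from compound 3 to compound 4 (0.03 log units; within the scatter), not beyond the scatter, with an estimated 1.3 L/kg and a range from 0.6 L/kg to 2.6 L/kg.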

Compound 4, volume of distribution: 0.9 L/kg
Compound 4: middle estimate off by 1.4-fold (0.16 log units), on the high side, within the range that was stated.
By their numbers in this assay, from the lowest: compounds 1, 4, 3 and 2 (each within the scatter of the next, the first and the last beyond it).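

Exchanging the aromatic 1,3-oxazol-4-yl for the non-aromatic oxolan-3-yl on this carbonyl carbon, with the heavy-atom count unchanged and one hydrogen-bond acceptor fewer, gives in this assay a 1.3-fold lower number from compound 3 to compound 4 (0.12 log units; within the scatter). Among these compounds, this is the first exchange of one ring for another at this place, and the read-out cannot separate the two groups. Nothing shown explains this result. Open, on these data alone, is whether an amine or a carboxylic acid on this carbonyl carbon would carry the number beyond the scatter, and whether the same exchange would read alike on the core of compound 1.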